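From Aminophenyl to Difluorophenyl on the Carbonyl Carbon

This account rests on a few compounds, and the source may have more. Where it says the series, first, only, none or still open, it means among the compounds named here.

Compound 1 `COc1cc(-c2cc(/C=C/C(=O)c3ccc(N)cc3)[nH]n2)cc(OC)c1OC` gives the lowest of the two numbers in a functional assay on MCF7 cells (Homo sapiens) for inhibition, read by MTT assay, with a stated time of 48 h (on this read-out higher numbers stand for weaker inhibition and lower numbers for stronger inhibition), at 1600 nM. Compound 2 `COc1cc(-c2cc(/C=C/C(=O)c3ccc(Cl)c(Cl)c3)[nH]n2)cc(OC)c1OC`, which carries 3,4-dichlorophenyl in place of 4-aminophenyl on a carbonyl carbon, gives 3200 nM in this assay; the step of a 2.0-fold higher number from compound 1 to compound 2 (0.30 log units; within the scatter) lies within the scatter, so the two cannot be ordered. Compound 3 `COc1cc(-c2cc(/C=C/C(=O)c3ccc(F)c(F)c3)[nH]n2)cc(OC)c1OC` has not yet been measured in this assay. It differs from compound 1 as follows: 3,4-difluorophenyl in place of 4-aminophenyl on a carbonyl carbon. Among the compounds with values here, the only measured step that bears on this change is a 2.0-fold higher number from compound 1 to compound 2 (0.30 log units; within the scatter), in which the same 4-aminophenyl gave way to 3,4-dichlorophenyl. Within the data shown here, with that as the sole guide, a small shift toward a higher number is expected, or none beyond the scatter. The expected step is a 1.6-fold higher number from compound 1 to compound 3 (0.19 log units; within the scatter). Compound 3 is therefore estimated at 2500 nM in this assay, with a range from 1000 nM to 6000 nM.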

Compound 3, half-maximal inhibitory concentration: 2500 nM
Beside the measured number, compound 3's estimate shows no gap at the digits printed; the measured number falls inside the stated range.
By their numbers in this assay, from the lowest: compounds 1, 3 and 2 (each within the scatter of the next).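

In this assay the change to 3,4-difluorophenyl on the carbonyl carbon gives a 1.6-fold higher number from compound 1 to compound 3 (0.19 log units; within the scatter) and so, like the change to 3,4-dichlorophenyl, does not separate the new compound from the one carrying 4-aminophenyl. The two dihalophenyl groups cannot be ordered either: the exchange of 3,4-dichlorophenyl for 3,4-difluorophenyl gives a 1.3-fold lower number from compound 2 to compound 3 (0.11 log units; within the scatter) and leaves them level within the scatter. At this position, then, 4-aminophenyl, with its hydrogen-bond donor and acceptor, gives way to 3,4-difluorophenyl, which is counted with neither, without a step beyond the scatter, and no evidence on the reason is available.

From the compounds shown here alone, it remains open whether any group on this carbonyl carbon can move the number beyond the scatter. A 4-methoxyphenyl, a 4-carboxyphenyl or a pyridine ring in place of the phenyl would extend the comparison.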